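The source may hold more compounds than are shown below. What is called first, only, known or untested is meant among the compounds shown, and "the series" means these compounds.

Measured compounds in a functional assay on HepG2 cells (Homo sapiens) for cytotoxicity, read by MTT assay, with a stated time of 72 h; on this read-out higher numbers stand for lower toxicity in this test and lower numbers for higher toxicity in this test:

compound 1 `C[Se]/C(=N\C(=O)c1cccs1)NC(=O)c1cccs1` gives 12500 nM
compound 2 `CS/C(=N\C(=O)c1cccs1)NC(=O)c1cccs1` gives > 100000 nM
compound 3 `C[Se]/C(=N\C(=O)c1cnc2ccccc2c1)NC(=O)c1cnc2ccccc2c1` gives 87800 nM

The value of compound 2 in this assay is a limit of the assay and not a number. Compound 1 and compound 2 differ by a group of 2 heavy atoms (1 carbon, 1 sulfur; no ring) in place of a group of 2 heavy atoms (1 carbon, 1 selenium; no ring), on a carbon with a double bond to nitrogen. That change gives an at least 8.0-fold higher number from compound 1 to compound 2 (0.90 log units; beyond the scatter). The size of the step is known only as a floor, since one value sits at the limit of > 100000 nM in this assay, at which 1 of the 3 values shown sits.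

Compound 3 carries a different core from compound 1; the difference between the two cores is not broken down here. In this assay compound 3 stands highest of the two numbers, with compound 1 as its nearest neighbour at a lower number, the gap lying beyond the scatter.

Compound 4 `CS/C(=N\C(=O)c1cnc2ccccc2c1)NC(=O)c1cnc2ccccc2c1` is not yet measured. It differs from compound 3 by a group of 2 heavy atoms (1 carbon, 1 sulfur; no ring) in place of a group of 2 heavy atoms (1 carbon, 1 selenium; no ring), on a carbon with a double bond to nitrogen. The place is the same as in the step from compound 1 to compound 2, so the change is the same one, made a second time. Compound 3 already sits close to the ceiling of the assay. A step of about the size seen from compound 1 to compound 2, an at least 8.0-fold higher number from compound 1 to compound 2 (0.90 log units; beyond the scatter), is expected from compound 3 to compound 4, as a 5.7-fold higher number from compound 3 to compound 4 (0.76 log units; beyond the scatter), resting on that single earlier step. The value of compound 4 in this assay is therefore expected to fall near 500000 nM, with a range from 100000 nM to 3000000 nM, and a reported limit rather than a number is likely.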

Compound 4, concentration lethal to 50% of the cells: > 100000 nM
Compound 4: no number, only a limit; the forecaster's own chance of this, stated with the estimate: 75%; the middle value is on the limit's open side.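

The exchange of the selenium-bearing group for methylsulfanyl, on a carbon with a double bond to nitrogen, has now been made on two cores. In this assay compound 4 gives > 100000 nM, which is a limit of the assay and not a number. The new step is an at least 1.1-fold higher number from compound 3 to compound 4 (0.05 log units; that floor lies within the scatter); it runs in the same direction as the earlier step but, taken alone, does not establish a change beyond the scatter on this core, and neither core gives a true size for the step, so whether the change carries over with the same size remains unsettled: the same change on two cores in this assay, an at least 8.0-fold higher number (0.90 log units; beyond the scatter) from compound 1 to compound 2 and an at least 1.1-fold higher number (0.05 log units; that floor lies within the scatter) from compound 3 to compound 4; the limit leaves it open whether they differ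

Going by these compounds, what the two methylsulfanyl compounds would give beyond the limit stays unknown, so the sulfur-bearing pair cannot be ranked and the effect of the core on these compounds cannot be read from them: the limit of > 100000 nM in this assay, at which 2 of the 4 values shown sit. Also open is how either core would respond to a different group on that same carbon, such as an amine or a longer chain on the sulfur or selenium, and whether such a group would give numbers that fall inside the range of the assay.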